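Bromo for benzyloxy in a series at the assay limit

The compounds below may be only part of what the source reports. "The series", "measured", "known", "first", "only" and "open" are said of these compounds alone.

Compound 3 `Cc1ccc(S(=O)(=O)n2cc(-c3cc(C(F)(F)F)ccn3)c3cc(OCc4ccccc4)ccc32)cc1` stands at the limit of a functional assay on P388 cells (Mus musculus) for cytotoxicity; on this read-out lower numbers stand for stronger inhibition and higher numbers for weaker inhibition. In this assay compound 3 gives > 100000 nM, which is a limit and not a number. Compound 1 `COc1ccc2c(c1)c(-c1cc(C(F)(F)F)ccn1)cn2S(=O)(=O)c1ccc(C)cc1` gives > 100000 nM in this assay, also a limit. Compound 2 `Cc1ccc(S(=O)(=O)n2cc(-c3cc(C(F)(F)F)ccn3)c3ccccc32)cc1` gives > 100000 nM in this assay, again a limit. All three values sit at the limit of > 100000 nM in this assay, at which 3 of the 3 values shown sit. The steps among them are therefore not readable: a step that the two limits leave unreadable from compound 1 to compound 2, a step that the two limits leave unreadable from compound 1 to compound 3 and a step that the two limits leave unreadable from compound 2 to compound 3 all lie between two limits, with no size to be taken from them.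

Compound 4 `Cc1ccc(S(=O)(=O)n2cc(-c3cc(C(F)(F)F)ccn3)c3cc(Br)ccc32)cc1` differs from compound 3 by bromo in place of benzyloxy on an aromatic carbon. Among the compounds with values here, the steps that bear on this position are the removal of the methoxy group, a step that the two limits leave unreadable from compound 1 to compound 2, and the entry of the benzyloxy group, a step that the two limits leave unreadable from compound 2 to compound 3; neither gives a readable size, so no direction of change can be read for this assay, and nothing suggests a number will appear.

For compound 4 the expectation is therefore that it remains at the limit, estimated at 100000 nM with a range from 30000 nM to 300000 nM. The step this estimate means is expected to be a number no higher from compound 3 to compound 4 (the limit leaves the size open), none beyond the scatter.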

Compound 4, half-maximal inhibitory concentration: > 100000 nM
Compound 4 ended at the assay's limit (the forecaster's own chance of this, stated with the estimate: 85%); the middle value sits exactly at the limit.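

Compound 4 gives > 100000 nM in this assay, which is a limit and not a number. The steps linking compound 1, compound 2, compound 3 and compound 4 therefore cannot be read: the limit of > 100000 nM in this assay, at which 4 of the 4 values shown sit.

The compounds shown leave open whether any group on this aromatic carbon gives a readable number, and how hydrogen, methoxy, benzyloxy and bromo rank.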